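The source may report more compounds than this note shows. Statements on the series, on what has been measured and on what is new or still open speak of the compounds shown alone.

Measured so far in a functional assay on the whole organism with Mus musculus as the target; on this read-out higher numbers stand for an effect only at larger amounts of compound and lower numbers for an effect already at smaller amounts:

- Compound 1 `NC(=O)/C=C/c1cccc(C(F)(F)F)c1`: 54.5 mg/kg
- Compound 2 `O=C(/C=C/c1cccc(C(F)(F)F)c1)NCCO`: 186 mg/kg
- Compound 3 `CCC(O)CNC(=O)/C=C/c1cccc(C(F)(F)F)c1`: 92.9 mg/kg

Compound 3 cannot be told apart from either of the other two, as the measurements show a 1.7-fold higher number from compound 1 to compound 3 (0.23 log units; within the scatter) and a 2.0-fold lower number from compound 2 to compound 3 (0.30 log units; within the scatter). The next compound, compound 4 `CN1CCN(C(=O)/C=C/c2cccc(C(F)(F)F)c2)CC1`, carries 4-methylpiperazin-1-yl in place of (2-hydroxybutyl)amino on a carbonyl carbon.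

The measured steps offer only a loose guide to this change. Each of them alters what sits on an amide-type nitrogen, but none introduces a ring. The largest of them is modest: a 3.4-fold higher number from compound 1 to compound 2 (0.53 log units; beyond the scatter). Going by the values given here, with no larger step to draw on, no change beyond the scatter is expected in this assay, and no direction can be favoured. Among the compounds with values here, the estimate therefore stays close to compound 3, with a wide range because no measured compound carries this ring.

The estimate amounts to an expected 1.1-fold higher number from compound 3 to compound 4 (0.03 log units; within the scatter).

For compound 4, the expected value is 100 mg/kg, with an estimated range from 40 mg/kg to 250 mg/kg.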

Compound 4, dose for half-maximal effect: > 100 mg/kg
Compound 4: a limit, no number (the forecaster's own chance of this, stated with the estimate: 10%); the middle value sits exactly at the limit.
By their numbers in this assay, from the lowest: compounds 1, 3 and 2 (each within the scatter of the next, the first and the last beyond it).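

In this assay compound 4, the only compound shown with a ring on the carbonyl carbon, gives a limit and not a number (> 100 mg/kg). Placing 4-methylpiperazin-1-yl there gives an at least 1.0-fold higher number from compound 3 to compound 4 (0.03 log units; that floor lies within the scatter) and also an at least 1.8-fold higher number from compound 1 to compound 4 (0.26 log units; that floor lies within the scatter) while the step from compound 2 cannot be read. The true size of these steps stays unknown, and their direction is only what the floors print, because of the limit: the limit of > 100 mg/kg in this assay, at which 1 of the 4 values shown sits.

Still open, going by these compounds, is whether piperazin-1-yl without its methyl, or a morpholine ring, would give a real number in this assay on this carbonyl carbon. An open-chain dimethylamino group could also show whether the ring itself or the loss of the amide hydrogen matters here.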